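Trading the hydroxynaphthyl group of compound 3 for methoxyphenyl

A few compounds are considered here, and "the series" means these few. Any claim that something is new, unique, unknown or untested is made for them only; others in the source may bear on it.

Of the compounds shown here, three built on one shared core have been measured in a functional assay on Ehrlich cells (Mus musculus) for cytotoxicity, tested at 100 ug/mL; on this read-out lower numbers stand for a weaker effect and higher numbers for a stronger effect at the one concentration tested. Compound 3 `COc1cc(N2C(N)=C(C#N)C(c3c(O)ccc4ccccc34)C3=C2CC(C)(C)CC3=O)cc(OC)c1OC` gives 90%, the highest of the three numbers. Compound 1 `COc1cc(N2C(N)=C(C#N)C(c3c(OC)ccc4ccccc34)C3=C2CC(C)(C)CC3=O)cc(OC)c1OC` gives 30%, and compound 2 `COc1cc(N2C(N)=C(C#N)C(c3ccccc3O)C3=C2CC(C)(C)CC3=O)cc(OC)c1OC` gives 10%. The step of a number 60 percentage points higher from compound 1 to compound 3 (beyond the scatter) shows the effect of hydrogen in place of methyl on an oxygen on an aromatic ring, the step of a number 20 percentage points lower from compound 1 to compound 2 (beyond the scatter) the effect of 2-hydroxyphenyl in place of 2-methoxynaphthalen-1-yl on a saturated ring carbon, and the step of a number 80 percentage points higher from compound 2 to compound 3 (beyond the scatter) the effect of 2-hydroxynaphthalen-1-yl in place of 2-hydroxyphenyl at the same position.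

Compound 4 `COc1ccccc1C1C(C#N)=C(N)N(c2cc(OC)c(OC)c(OC)c2)C2=C1C(=O)CC(C)(C)C2` has not yet been measured. It differs from compound 3 as follows: 2-methoxyphenyl in place of 2-hydroxynaphthalen-1-yl on a saturated ring carbon. This single change brings together the methyl on the oxygen, which compound 1 carries, and the one-ring group, which compound 2 carries, and each of those two compounds sits well below compound 3. Compound 4 is therefore expected to fall far below compound 3, a number 80 percentage points lower from compound 3 to compound 4 (beyond the scatter). In this assay compound 4 is estimated to give about 10%, with a range from 0% to 30%.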

Compound 4, a percentage reported as activity, at one concentration (the size of the read-out at that concentration, not a potency): 100%
Compound 4: middle estimate off by 90 percentage points, on the low side; measured number above the stated range.
By their numbers in this assay, from the lowest: compound 2; then compound 1; then compounds 3 and 4 (each within the scatter of the next).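

In this assay, replacing 2-hydroxynaphthalen-1-yl with 2-methoxyphenyl on the saturated ring carbon gives a number 10 percentage points higher from compound 3 to compound 4 (within the scatter), so at this position the two groups cannot be told apart, although the change combines two features that each accompanied a lower number in an earlier compound. Neither feature lowers the number on its own: adding the methyl to the oxygen of the one-ring group gives a number 90 percentage points higher from compound 2 to compound 4 (beyond the scatter), and going from 2-methoxynaphthalen-1-yl to 2-methoxyphenyl gives a number 70 percentage points higher from compound 1 to compound 4 (beyond the scatter). The result of swapping hydrogen for methyl on this oxygen therefore depends on the group that carries it, and the two changes do not simply add up: the same change on two cores in this assay runs in opposite directions, as follows: the same change on two cores in this assay, a number 60 percentage points higher (beyond the scatter) from compound 1 to compound 3 and a number 90 percentage points lower (beyond the scatter) from compound 4 to compound 2, 150 percentage points apart, beyond the scatter of two such steps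

The compounds shown leave open whether this high level needs the methoxy group at all, or whether a plain phenyl, an ethoxy chain or an amine on the ring would hold it. With a single concentration, and compound 3 and compound 4 within the scatter of each other, the read-out also leaves open whether the two differ in potency.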